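Cyclopropyl-amino purine acetamides: amino acid side chain variation

The source may hold more compounds than are shown below. What is called first, only, known or untested is meant among the compounds shown, and "the series" means these compounds.

Measured compounds:
compound 1 `O=C(CN(c1nc(Cl)nc2[nH]cnc12)C1CC1)N[C@@H](CO)C(=O)O`: 43.9%
compound 2 `O=C(O)CNC(=O)CN(c1nc(Cl)nc2[nH]cnc12)C1CC1`: 32.3%
compound 3 `O=C(O)C[C@H](NC(=O)CN(c1nc(Cl)nc2[nH]cnc12)C1CC1)C(=O)O`: 25.1%

In a functional assay on the whole organism (Tail, strain ICR) with Mus musculus as the target, in the tail flick test, with a stated time of 90 min, at a dose of 25 umol/kg by the oral route (a lower number here means a weaker effect, a higher number a stronger effect of the compound at the dose given), compound 3 gives 25.1%, a number that lies beyond the scatter below compound 1 and within the scatter of compound 2. Compound 4 `CC(C)C[C@H](NC(=O)CN(c1nc(Cl)nc2[nH]cnc12)C1CC1)C(=O)O` has not been measured in this assay. Its change from compound 3 is isopropyl in place of carboxy on a saturated chain carbon, two bonds along the chain from an amide-type nitrogen and a carbonyl carbon.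

Going by the values given here, two measured steps bear on this change. The step of a number 18.8 percentage points lower from compound 1 to compound 3 (beyond the scatter) shows that entry of a carboxy group at this place on the chain went with a lower number. The step of a number 7.2 percentage points lower from compound 2 to compound 3 (within the scatter) shows that adding the carboxymethyl chain at all stayed within the scatter. Among the compounds with values here, removing the carboxy group again, and putting isopropyl in its place, is therefore expected to recover part of what was lost from compound 1 to compound 3, giving a modest rise in this assay, though no measured step shows isopropyl itself.

Compound 4 is estimated at 37%, with a range of 22% to 55%. This estimate means a step of a number 11.9 percentage points higher from compound 3 to compound 4 (beyond the scatter).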

Compound 4, a percentage reported as activity, at one dose (the size of the read-out at that dose, not a potency): 27%
The estimate for compound 4 lay 10 percentage points above the measured number; measured number inside the range.
By their numbers in this assay, from the lowest: compounds 3, 4 and 2 (each within the scatter of the next); then compound 1.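

In this assay, isopropyl in place of carboxy on the saturated chain carbon, two bonds along the chain from an amide-type nitrogen and a carbonyl carbon, gives no separation (a number 1.9 percentage points higher from compound 3 to compound 4 (within the scatter)), so removing the carboxy group does not recover the gap to compound 1. Isobutyl in place of hydrogen also leaves the number within the scatter (a number 5.3 percentage points lower from compound 2 to compound 4 (within the scatter)), whereas the comparison with the hydroxy-bearing side chain stays beyond it (a number 16.9 percentage points lower from compound 1 to compound 4 (beyond the scatter)); among these four compounds, only compound 1 stands apart. Nothing measured here explains this separation.

As far as these compounds go, whether the hydroxy group or the carbon chain carrying it sets compound 1 apart remains open. A methoxymethyl group, an aminomethyl group or a longer hydroxyalkyl chain at this place would bear on that question.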